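The source may hold more compounds than are shown below. What is called first, only, known or untested is meant among the compounds shown, and "the series" means these compounds.

Measured compounds:
compound 1 `C=C[C@](C)(O)CC[C@H]1C(C)=CC[C@H]2C(C)(C)CCC[C@]12C`, 8.7 ug/mL
compound 2 `C=C[C@@](C)(CC[C@@H]1[C@@]2(C)CCCC(C)(C)[C@@H]2CC[C@@]1(C)O)O[C@H]1O[C@H](C)[C@H](O)[C@@H](O)[C@@H]1O`, > 5 ug/mL
compound 3 `C=C[C@](C)(O)CC[C@H]1C(=C)[C@H](O)C[C@H]2C(C)(C)CCC[C@]12C`, > 5 ug/mL

Going by the values given here, in a functional assay on SK-OV-3 cells (Homo sapiens) for cytotoxicity, read by sulforhodamine B assay (a higher number here means that more compound is needed for the effect, a lower number that less compound is needed), compound 1 gives 8.7 ug/mL, the only numeric value among the three. For compound 2 the result > 5 ug/mL is a limit of this assay, not a number. For compound 3 the result > 5 ug/mL is likewise a limit. Among the compounds with values here, no pair of measured compounds differs in one place, so no step is available; what is known is the limit of > 5 ug/mL in this assay, at which 2 of the 3 values shown sit.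

Compound 4 `C=C[C@@](C)(CC[C@H]1C(C)=CC[C@H]2C(C)(C)CCC[C@]12C)O[C@@H]1O[C@@H](C)[C@@H](O)[C@H](O)[C@H]1O` keeps the core of compound 1 and differs by a group of 10 heavy atoms (6 carbon, 4 oxygen; one six-membered non-aromatic ring with 1 hetero atom) in place of a hydrogen atom, on an oxygen on a saturated carbon. Given that compound 2, also a glycoside, sits at the limit > 5 ug/mL, the expected step from compound 1 to compound 4 is a 1.7-fold higher number from compound 1 to compound 4 (0.24 log units; within the scatter), toward a higher value. For compound 4 the estimate is 15 ug/mL, expected between 5 ug/mL and 50 ug/mL.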

Compound 4, concentration for half-maximal effect: 5.7 ug/mL
Compound 4: middle estimate off by 2.6-fold (0.42 log units), on the high side; the measured number falls inside the stated range.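

In this assay, putting the group of 10 heavy atoms in place of the hydrogen atom, on an oxygen on a saturated carbon, gives a 1.5-fold lower number from compound 1 to compound 4 (0.18 log units; within the scatter). Going by these compounds alone, this is the first readable step, and it shows that this position carries a group of that size with no shift beyond the scatter.

From the compounds shown here alone, whether a small acetyl group or an amine-bearing sugar at this oxygen would read the same stays open. Comparisons across the rest of the series also remain thin: the limit of > 5 ug/mL in this assay, at which 2 of the 4 values shown sit.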